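This account rests on a few compounds, and the source may have more. Where it says the series, first, only, none or still open, it means among the compounds named here.

In a functional assay on Caco-2 cells (Homo sapiens), read by MTT assay, with a stated time of 48 h (a lower number here means a stronger inhibitor, a higher number a weaker inhibitor), compound 1 (`CCN(CC)CCCNC(=O)c1ccc(C(CC)(CC)c2ccc(OCC(O)C(C)(C)C)c(C)c2)n1CC`) gives 1800 nM and compound 2 (`CCn1c(C(=O)NCCN)ccc1C(CC)(CC)c1ccc(OCC(O)C(C)(C)C)c(C)c1`) gives 1000 nM. These two numbers lie within the usual scatter of each other, so the data do not separate the two compounds. Compound 3 (`C=CCN(C)C(=O)c1ccc(C(CC)(CC)c2ccc(OCC(O)C(C)(C)C)c(C)c2)n1CC`) alters compound 2 at one place: allyl(methyl)amino in place of (2-aminoethyl)amino on a carbonyl carbon. Put simply, allyl(methyl)amino stands in place of (2-aminoethyl)amino on a carbonyl carbon. Among the measured compounds shown here, only one measured step offers any guidance: a 1.8-fold lower number from compound 1 to compound 2 (0.26 log units; within the scatter). That step put amino in place of (diethylamino)methyl, while the new change removes the whole (2-aminoethyl)amino group, so the step is only a weak guide. For the measured compounds named here, no measured pair shows this exact swap. The estimated size is a 2.5-fold higher number from compound 2 to compound 3 (0.40 log units; beyond the scatter), towards a modestly higher number in this assay, and it is uncertain. For compound 3 the expected value is 2500 nM, with an estimated range from 800 nM to 8000 nM.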

Compound 3, half-maximal inhibitory concentration: > 50000 nM
Compound 3 gave a limit, no number; the forecaster's own chance of this, stated with the estimate: 15%; middle value at least 20-fold (1.30 log units) from the limit.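

The value of compound 3 is a limit of the assay and not a number: the limit of > 50000 nM in this assay, at which 1 of the 3 values shown sits. On this carbonyl carbon, allyl(methyl)amino in place of (2-aminoethyl)amino gives an at least 50-fold higher number from compound 2 to compound 3 (1.69 log units; beyond the scatter), and in place of (3-(diethylamino)propyl)amino it gives an at least 27-fold higher number from compound 1 to compound 3 (1.44 log units; beyond the scatter). The earlier pair, both carrying an amine on their chain, stayed within the scatter of each other, so they gave no sign that this position could matter so much; compound 3 shows that this one swap can cost most of the measurable activity.

The swap removes the chain amine and the amide hydrogen together, and adds an allyl group, so the compounds shown cannot say which of these changes counts. From the compounds shown here alone, it also remains open whether a hydroxyl or a carboxylic acid at the end of a chain on a hydrogen-bearing amide would stay close to compound 2.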